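From 2-chlorophenyl to 4-chlorophenyl in compound 1

A few compounds are considered here, and "the series" means these few. Any claim that something is new, unique, unknown or untested is made for them only; others in the source may bear on it.

In a functional assay on T47D cells (Homo sapiens) for cytotoxicity, read by CCK-8 assay and cell counting, with a stated time of 2 days (on this read-out lower numbers stand for stronger inhibition and higher numbers for weaker inhibition), compound 1 `Oc1ccc(-c2cc(-c3ccccc3)nc(-c3ccccc3Cl)c2)cc1` gives 5460 nM while compound 2 `Oc1ccc(-c2cc(-c3cccs3)nc(-c3ccccc3Cl)c2)cc1` gives 5870 nM and compound 3 `Oc1ccc(-c2cc(-c3ccco3)nc(-c3ccccc3Cl)c2)cc1` gives 5480 nM in the same test. Compound 1 therefore stands level with both, all three lying within the scatter. Compound 4 `Oc1ccc(-c2cc(-c3ccccc3)nc(-c3ccc(Cl)cc3)c2)cc1` carries 4-chlorophenyl in place of 2-chlorophenyl on an aromatic carbon and is otherwise unchanged. Among the compounds with values here, only two measured steps start from compound 1: thiophen-2-yl for phenyl (a 1.1-fold higher number from compound 1 to compound 2 (0.03 log units; within the scatter)) and furan-2-yl for phenyl (a 1.0-fold higher number from compound 1 to compound 3 (0.00 log units; within the scatter)). Both are within the scatter, but neither touches the chlorophenyl group, so they guide this change only loosely. The expected change is a 1.1-fold lower number from compound 1 to compound 4 (0.04 log units; within the scatter) and no shift beyond the scatter is expected. For compound 4 the estimated value is 5000 nM with a wide expected range from 1700 nM to 15000 nM in this test.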

Compound 4, half-maximal inhibitory concentration: 4270 nM
For compound 4 the middle estimate is 1.2-fold (0.07 log units) above the measured one; the measured number falls inside the stated range.
By their numbers in this assay, from the lowest: compounds 4, 1, 3 and 2 (each within the scatter of the next).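

Within the data shown here, this is the first measured change to the chlorophenyl group itself, the group next to the ring nitrogen. In this assay, 4-chlorophenyl in place of 2-chlorophenyl gives a 1.3-fold lower number from compound 1 to compound 4 (0.11 log units; within the scatter) and so, for this pair, where the chlorine sits on that ring makes no difference that can be told from the scatter. No measurement at hand explains this result.

The compounds shown leave open whether a different group at this position, such as a phenyl ring carrying an amine or a carboxylic acid instead of chlorine, would shift the number beyond the scatter.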